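Swapping 4-nitrophenyl for 3,4-dichlorophenyl: working notes

This account rests on a few compounds, and the source may have more. Where it says the series, first, only, none or still open, it means among the compounds named here.

Values in an ADME assay on L6 cells (Rattus norvegicus) for cytotoxicity, read by fluorescence and resazurin assay, with a stated time of 72 h; a higher number here means that more compound is tolerated, a lower number that less compound is tolerated:
- compound 1 `N#Cc1ccc(-c2c[nH]cc2C(c2ccc(Cl)cc2Cl)n2ccnc2)cc1`: 15000 nM
- compound 2 `O=[N+]([O-])c1ccc(-c2c[nH]cc2C(c2ccc(Cl)cc2Cl)n2ccnc2)cc1`: 16900 nM

In this assay compound 2 stands at 16900 nM, level with compound 1 within the scatter. Compound 3 `Clc1ccc(C(c2c[nH]cc2-c2ccc(Cl)c(Cl)c2)n2ccnc2)c(Cl)c1` carries 3,4-dichlorophenyl in place of 4-nitrophenyl on an aromatic carbon. Among the compounds with values here, only one measured step bears on this change: a 1.1-fold higher number from compound 1 to compound 2 (0.05 log units; within the scatter), with nitro in place of cyano on an aromatic carbon. Within the data shown here, that step stayed within the scatter, but it offers only partial guidance, as no measured compound carries 3,4-dichlorophenyl at this place. The range is therefore kept wide. The expected step is a 1.5-fold lower number from compound 2 to compound 3 (0.19 log units; within the scatter), leaning slightly to a lower number and not beyond the scatter. Compound 3 is estimated at 11000 nM, with an expected range of 4000 nM to 25000 nM.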

Compound 3, half-maximal cytotoxic concentration: 3640 nM
Beside the measured number, compound 3's estimate is 3.0-fold (0.48 log units) above it; the measured number lies below the stated range.
By their numbers in this assay, from the lowest: compound 3; then compounds 1 and 2 (each within the scatter of the next).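

In this assay this place on the five-membered aromatic ring proves sensitive to the aryl group it carries: 3,4-dichlorophenyl in place of 4-nitrophenyl gives a 4.6-fold lower number from compound 2 to compound 3 (0.67 log units; beyond the scatter) and 3,4-dichlorophenyl in place of 4-cyanophenyl gives a 4.1-fold lower number from compound 1 to compound 3 (0.61 log units; beyond the scatter) in the same direction. The exchange of nitro for cyano had stayed within the scatter, so only the dichlorophenyl compound shows that the group here can move the tolerated concentration beyond it. Nothing at hand accounts for this shift.

The compounds shown leave open whether one chlorine on the phenyl ring would give the same lower number as the two in compound 3. They also leave open how a phenyl ring bearing an amine or a carboxylic acid at this place would stand in this assay against these three compounds.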